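The compounds below may be only part of what the source reports. "The series", "measured", "known", "first", "only" and "open" are said of these compounds alone.

Measured so far:
Compound 1 `CCCC[C@]1(CC)CS(=O)(=O)c2ccc(NO)cc2[C@@H](c2ccccc2)[C@H]1O` — 260 nM
Compound 2 `CCCC[C@]1(CC)CS(=O)(=O)c2ccc(NC(=O)OCc3ccccc3)cc2[C@@H](c2ccccc2)[C@H]1O` — 400 nM
Compound 3 `CCCC[C@]1(CC)CS(=O)(=O)c2ccc(NC(C)=O)cc2[C@@H](c2ccccc2)[C@H]1O` — 90 nM

In an assay on cells for inhibition of ileal sodium/bile acid cotransporter (Homo sapiens) (on this read-out lower numbers stand for stronger inhibition and higher numbers for weaker inhibition), compound 3 gives the lowest number of the three; its steps to the others, a 2.9-fold lower number from compound 1 to compound 3 (0.46 log units; beyond the scatter) and a 4.4-fold lower number from compound 2 to compound 3 (0.65 log units; beyond the scatter), both lie beyond the scatter. Compound 4 `CCCC[C@]1(CC)CS(=O)(=O)c2ccc([N+](C)(C)C)cc2[C@@H](c2ccccc2)[C@H]1O` departs from it by a group of 4 heavy atoms (3 carbon, 1 nitrogen; no ring) in place of a group of 4 heavy atoms (2 carbon, 1 nitrogen, 1 oxygen; no ring), on an aromatic carbon. Among the compounds with values here, the steps that bear on this place are a 2.9-fold lower number from compound 1 to compound 3 (0.46 log units; beyond the scatter), a 1.5-fold higher number from compound 1 to compound 2 (0.19 log units; within the scatter) and a 4.4-fold lower number from compound 2 to compound 3 (0.65 log units; beyond the scatter): changing the group on that aromatic carbon has moved the number by modest amounts, in either direction. The new group shares nothing with the acetamido it replaces, so the step is expected to be of similar modest size, most likely towards a higher number, a 5.6-fold higher number from compound 3 to compound 4 (0.74 log units; beyond the scatter). Compound 4 is therefore expected to give about 500 nM in this assay, within 120 nM to 2500 nM.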

Compound 4, half-maximal inhibitory concentration: 83 nM
Estimate against measurement, compound 4: 6.0-fold (0.78 log units) above, and the stated range ends above it.
By their numbers in this assay, from the lowest: compounds 4 and 3 (each within the scatter of the next); then compounds 1 and 2 (each within the scatter of the next).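

In this assay, the step of a 1.1-fold lower number from compound 3 to compound 4 (0.04 log units; within the scatter) shows that this aromatic carbon accepts a group of net charge +1 with no hydrogen-bond donors or acceptors about as well as it accepts the uncharged acetamido. The amide hydrogen and carbonyl of compound 3 are therefore not required to reach this level. The charged group also compares well with the two other nitrogen groups, with a 4.8-fold lower number from compound 2 to compound 4 (0.68 log units; beyond the scatter) and a 3.1-fold lower number from compound 1 to compound 4 (0.50 log units; beyond the scatter) both beyond the scatter.

No measurement shown explains this result. On these data alone, how a plain amine, a dimethylamino group or a carboxylic acid would behave on this carbon remains open.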